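Swapping the Carbamate Arm of Compound 1 for Phenyl

This account rests on a few compounds, and the source may have more. Where it says the series, first, only, none or still open, it means among the compounds named here.

Among the compounds with values here, compound 1 `COc1ccc(N(CC(=O)NCCC[Te]c2ccccc2)C(=O)CNC(=O)OC(C)(C)C)cc1` shows the highest of the two numbers so far: in a functional assay on A549 cells (Homo sapiens) for inhibition, with a stated time of 48 h (a lower number here means that less compound is tolerated, a higher number that more compound is tolerated), compound 1 gives 6760 nM. Compound 2 `COc1ccc(N(CC(=O)NCCC[Te]c2ccccc2)C(=O)CCSC2=C(C)C(=O)c3ccccc3C2=O)cc1` gives 3470 nM in this assay, a value within the scatter of that of compound 1. Compound 3 `COc1ccc(N(CC(=O)NCCC[Te]c2ccccc2)C(=O)c2ccccc2)cc1` has not been measured. It differs from compound 1 by phenyl in place of ((tert-butoxycarbonyl)amino)methyl on a carbonyl carbon. Among the measured compounds no change of this kind has been followed, and the step is expected to be none beyond the scatter. Compound 3 is therefore expected at 5000 nM, within a range from 1500 nM to 16000 nM, an estimated step of a 1.4-fold lower number from compound 1 to compound 3 (0.13 log units; within the scatter).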

Compound 3, concentration lethal to 50% of the cells: 17800 nM
Beside the measured number, compound 3's estimate is 3.6-fold (0.55 log units) below it, and the stated range ends below it.
By their numbers in this assay, from the lowest: compounds 2 and 1 (each within the scatter of the next); then compound 3.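

Within the data shown here, on the carbonyl carbon whose other neighbours are the amide-type nitrogen, phenyl in place of ((tert-butoxycarbonyl)amino)methyl gives, in this assay, a 2.6-fold higher number from compound 1 to compound 3 (0.42 log units; beyond the scatter), the only step read so far. The group on this carbon therefore does change the number, and here the change is modest and towards more compound being tolerated. Nothing measured here accounts for the step. On these data alone, what an aminomethyl group, a carboxylic acid or a pyridine ring would give on this carbonyl carbon stays open. Also open, as far as these compounds go, is whether the step from compound 1 to compound 3 would hold on another core.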